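Nitro to fluoro on the aromatic carbonyl group

The source may report more compounds than this note shows. Statements on the series, on what has been measured and on what is new or still open speak of the compounds shown alone.

In a functional assay on MGC-803 cells (Homo sapiens) for cytotoxicity, read by MTT assay, with a stated time of 72 h (on this read-out higher numbers stand for weaker inhibition and lower numbers for stronger inhibition), compound 1 (`C=C1C(=O)[C@@]23C(=O)OC[C@]4(C(=O)CCC(C)(C)[C@H]4C=O)[C@@H]2CC[C@@H]1[C@H]3OC(=O)CC`) gives 1780 nM and compound 2 (`C=C1C(=O)[C@@]23C(=O)OC[C@]4(C(=O)CCC(C)(C)[C@H]4C=O)[C@@H]2CC[C@@H]1[C@H]3OC(=O)c1ccc(C)cc1`) gives 2240 nM while compound 3 (`C=C1C(=O)[C@@]23C(=O)OC[C@]4(C(=O)CCC(C)(C)[C@H]4C=O)[C@@H]2CC[C@@H]1[C@H]3OC(=O)c1ccc([N+](=O)[O-])cc1`) gives 3330 nM and so lies within the scatter of both others. Compound 4 (`C=C1C(=O)[C@@]23C(=O)OC[C@]4(C(=O)CCC(C)(C)[C@H]4C=O)[C@@H]2CC[C@@H]1[C@H]3OC(=O)c1ccc(F)cc1`) carries fluoro in place of nitro on an aromatic carbon. The closest evidence is the exchange at that same place, where a 1.5-fold higher number from compound 2 to compound 3 (0.17 log units; within the scatter) is the whole effect seen. The exchange on the carbonyl carbon gave a 1.9-fold higher number from compound 1 to compound 3 (0.27 log units; within the scatter) and a 1.3-fold higher number from compound 1 to compound 2 (0.10 log units; within the scatter) as well, so no step beyond the scatter is expected. The expected step in this assay is a 1.3-fold lower number from compound 3 to compound 4 (0.12 log units; within the scatter) and it stays inside the scatter. For compound 4 the estimated value is 2500 nM with an expected range of 1200 nM to 5000 nM in this series.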

Compound 4, half-maximal inhibitory concentration: 3960 nM
The estimate for compound 4 lay 1.6-fold (0.20 log units) below the measured number, within the range that was stated.
By their numbers in this assay, from the lowest: compounds 1, 2, 3 and 4 (each within the scatter of the next, the first and the last beyond it).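

In this assay, the aromatic carbon tolerates fluoro in place of nitro, with a 1.2-fold higher number from compound 3 to compound 4 (0.08 log units; within the scatter), and fluoro in place of methyl, with a 1.8-fold higher number from compound 2 to compound 4 (0.25 log units; within the scatter), so all three groups tested there read alike. Exchange of ethyl for 4-fluorophenyl on the carbonyl carbon gives the first step beyond the scatter, though a modest one, with a 2.2-fold higher number from compound 1 to compound 4 (0.35 log units; beyond the scatter). No measurement here bears on why this step exceeds the scatter. Open, on these data alone, is whether an amine or a carboxylic acid on that aromatic carbon, or a longer chain in place of ethyl, would shift the number further.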